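A few compounds are considered here, and "the series" means these few. Any claim that something is new, unique, unknown or untested is made for them only; others in the source may bear on it.

Series notes. Compound 1 `[O-][n+]1cccc(Oc2ccccc2)c1` is measured in a functional assay on the whole organism with Mus musculus as the target, in the maximal electroshock model, with a stated time of 30 min (on this read-out higher numbers stand for an effect only at larger amounts of compound and lower numbers for an effect already at smaller amounts), at 100 mg/kg, the lowest of the two numbers in hand. Compound 3 `O=Cc1cc[n+]([O-])cc1Oc1ccccc1`, which carries formyl in place of hydrogen on an aromatic carbon, gives 300 mg/kg in this assay. Compound 2 `[O-][n+]1ccc(Cl)c(Oc2ccccc2)c1` reaches only the limit of this assay, reported as > 300 mg/kg. Both measured replacements of hydrogen on the core of compound 1 move the number upward: an at least 3.0-fold higher number from compound 1 to compound 2 (0.47 log units; beyond the scatter) and a 3.0-fold higher number from compound 1 to compound 3 (0.48 log units; beyond the scatter); between the two substituted compounds, a number no higher from compound 2 to compound 3 (the limit leaves the size open).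

Compound 4 `CCc1cc[n+]([O-])cc1Oc1ccccc1` is not yet measured; it differs from compound 1 by ethyl in place of hydrogen on an aromatic carbon. Ethyl enters at the same aromatic carbon where chloro and formyl each gave a higher number than compound 1, so a modest upward step in this assay is expected for compound 4 as well, with the size left open by the limit on compound 2. The step expected is a 2.0-fold higher number from compound 1 to compound 4 (0.30 log units; within the scatter). Compound 4 is estimated at 200 mg/kg in this assay, with a range from 80 mg/kg to 400 mg/kg.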

Compound 4, minimum effective dose: 30 mg/kg
Compound 4: the middle estimate sits 6.7-fold (0.82 log units) above what was measured; the whole stated range lies above it.
By their numbers in this assay, from the lowest: compound 4; then compound 1; then compound 3.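

At the aromatic carbon opposite the ring nitrogen, replacing hydrogen does not push the number in one direction: with ethyl, this assay gives a 3.3-fold lower number from compound 1 to compound 4 (0.52 log units; beyond the scatter), against the upward steps seen with chloro and formyl. The group at this one carbon decides the direction, as ethyl in place of formyl gives a 10-fold lower number from compound 3 to compound 4 (1.00 log units; beyond the scatter). Ethyl in place of chloro gives an at least 10-fold lower number from compound 2 to compound 4 (1.00 log units; beyond the scatter), but the value of compound 2 is a limit and not a number: the limit of > 300 mg/kg in this assay, at which 1 of the 4 values shown sits.

From the compounds shown here alone, whether the lower number belongs to ethyl alone or extends to methyl, propyl or a longer chain remains open. Also open, going by these compounds, is how a methoxy group, an amine or a carboxylic acid at this carbon would read, so one ethyl compound sets no trend.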